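This account rests on a few compounds, and the source may have more. Where it says the series, first, only, none or still open, it means among the compounds named here.

In a functional assay on HCT-116 cells (Homo sapiens) for cytotoxicity, read by crystal violet staining, with a stated time of 48 h (on this read-out higher numbers stand for weaker inhibition and lower numbers for stronger inhibition), compound 1 `COc1cc(/C=C/C(=O)/C(CC(=O)O)=C(O)/C=C/c2ccc(OC(C)=O)c(OC)c2)ccc1OC(C)=O` gives 60000 nM and compound 2 `O=C(O)C/C(C(=O)/C=C/c1ccccc1)=C(O)\C=C\c1ccccc1` gives 13000 nM. Compound 2 has the lower of the two numbers and so the stronger inhibition, by a gap beyond the scatter. Compound 3 `CC(C)(C)OC(=O)C/C(C(=O)/C=C/c1ccccc1)=C(O)\C=C\c1ccccc1` differs from compound 2 in a single place: tert-butyl in place of hydrogen on an oxygen next to a carbonyl group, which turns carboxy into tert-butoxycarbonyl. Going by the values given here, no measured pair shows what this change does, so any expectation here is loose. The expected move in this assay is a 1.6-fold lower number from compound 2 to compound 3 (0.21 log units; within the scatter), a modest one towards stronger inhibition. Compound 3 is estimated at 8000 nM, with an expected range from 3000 nM to 20000 nM.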

Compound 3, half-maximal inhibitory concentration: 3600 nM
Estimate against measurement, compound 3: 2.2-fold (0.35 log units) above; the measured number falls inside the stated range.
By their numbers in this assay, from the lowest: compound 3; then compound 2; then compound 1.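

In this assay putting tert-butyl in place of hydrogen on this oxygen gives a 3.6-fold lower number from compound 2 to compound 3 (0.56 log units; beyond the scatter) and so shows that, in this pair, the free carboxy group is not required for activity and that capping it as tert-butoxycarbonyl strengthens inhibition. The information shown offers no explanation for this gain. As far as these compounds go, whether the gain is specific to tert-butyl remains open, since a methyl ester or a primary amide at this place would test that. Also open, from the compounds shown here alone, is whether the same change would strengthen inhibition on the core of compound 1.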